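Amide nitrogen substituents on the chlorophenyl series

A few compounds are considered here, and "the series" means these few. Any claim that something is new, unique, unknown or untested is made for them only; others in the source may bear on it.

Compound 1 `CC(C)C(C(N)=O)c1ccc(Cl)cc1` and compound 2 `CC(C)[C@H](C(=O)Nc1ccccc1)c1ccc(Cl)cc1` both give limits in a functional assay on CHO cells for agonist activity at Free fatty acid receptor 2 (Homo sapiens), read by cAMP accumulation; a higher number here means a weaker inhibitor, a lower number a stronger inhibitor. Compound 1 gives the limit > 100000 nM. Compound 2 gives the limit > 100000 nM. Among the compounds with values here, compound 3 `CC(C)C(C(=O)Nc1ncccn1)c1ccc(Cl)cc1` gives 53000 nM in this assay, the only number among the three. The other two values are limits, so compound 3 stands alone as a measured value. Within the data shown here, the step of an at least 1.8-fold lower number from compound 1 to compound 3 (0.27 log units; that floor lies within the scatter) is the only measured step, with the limit of > 100000 nM in this assay, at which 2 of the 3 values shown sit, as the floor for it.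

Compound 4 `CC(C)C(C(=O)Nc1cnccn1)c1ccc(Cl)cc1` differs from compound 3 by pyrazin-2-yl in place of pyrimidin-2-yl on an amide-type nitrogen. The two have the same atoms, joined differently; each group is one six-membered aromatic ring with 2 hetero atoms, 0 hydrogen-bond donors and 2 hydrogen-bond acceptors. Among the measured compounds shown here, no measured step covers an exchange between two such rings; the only measured step shows that putting pyrimidin-2-yl on the amide-type nitrogen gave the single number seen. From this, no step beyond the scatter is expected in this assay, in either direction, and compound 4 is estimated at 60000 nM (range 20000 nM to 150000 nM), an expected step of a 1.1-fold higher number from compound 3 to compound 4 (0.05 log units; within the scatter).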

Compound 4, half-maximal inhibitory concentration: 5700 nM
Compound 4: the middle estimate sits 11-fold (1.02 log units) above what was measured, and the stated range ends above it.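

On the amide-type nitrogen, the way the ring atoms are joined matters in this assay: pyrazin-2-yl in place of pyrimidin-2-yl gives a 9.3-fold lower number from compound 3 to compound 4 (0.97 log units; beyond the scatter), although both groups have the same atoms and the same counts of hydrogen-bond donors and acceptors. Pyrazin-2-yl in place of hydrogen gives an at least 17-fold lower number from compound 1 to compound 4 (1.24 log units; beyond the scatter), so a ring on this nitrogen now gives a step from hydrogen that lies beyond the scatter, which the step to pyrimidin-2-yl did not. That step is a floor and not a full size, as it starts from a limit: the limit of > 100000 nM in this assay, at which 2 of the 4 values shown sit.

The compounds shown do not tell which feature of pyrazin-2-yl goes with the lower number. A pyridin-2-yl or pyrimidin-4-yl group on the amide-type nitrogen would bear on that question.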